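The source may hold more compounds than are shown below. What is called first, only, known or untested is meant among the compounds shown, and "the series" means these compounds.

Measured compounds:
- compound 1 `CC1=NC(C)=C([N+](=O)[O-])C(c2ccncc2)/C1=C(\O)OC1CCCC1`; in a functional assay (cardiac atrium) for agonist activity, with Cavia porcellus as the target (a lower number here means that less compound is needed, a higher number that more compound is needed for the effect), compound 1 gives 4250 nM.
- compound 2 `CC1=NC(C)=C([N+](=O)[O-])C(c2ccncc2)/C1=C(\O)OC(C)C`; in this assay compound 2 gives 8050 nM.
- compound 3 `CCO/C(O)=C1\C(C)=NC(C)=C([N+](=O)[O-])C1c1ccncc1`; in this assay compound 3 gives 6460 nM.

Compound 3 stands second highest of the three numbers. Its nearest neighbour is compound 2, with a 1.2-fold lower number from compound 2 to compound 3 (0.10 log units; within the scatter); the furthest is compound 1, with a 1.5-fold higher number from compound 1 to compound 3 (0.18 log units; within the scatter). All three numbers therefore sit within the scatter of one another, and no ordering among them can be read from the data.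

Compound 4 `CC1=NC(C)=C([N+](=O)[O-])C(c2ccncc2)/C1=C(\O)OC1CCCCC1` is not yet measured. It differs from compound 3 in one place: cyclohexyl in place of ethyl on an oxygen on an unsaturated carbon. For the measured compounds named here, the steps that bear on this change are those that vary the same group on the oxygen on an unsaturated carbon: a 1.9-fold higher number from compound 1 to compound 2 (0.28 log units; within the scatter) and a 1.5-fold higher number from compound 1 to compound 3 (0.18 log units; within the scatter). Cyclopentyl, isopropyl and ethyl at that position gave numbers within the scatter of each other, so a further change to cyclohexyl is expected to give no step beyond the scatter in this assay, in either direction.

For compound 4 the estimated value in this assay is 5000 nM, with a range from 1500 nM to 16000 nM. The step this estimate implies is expected to be a 1.3-fold lower number from compound 3 to compound 4 (0.11 log units; within the scatter).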

Compound 4, half-maximal effective concentration: 4940 nM
Compound 4: the middle estimate sits 1.0-fold (0.01 log units) above what was measured; the measured number falls inside the stated range.
By their numbers in this assay, from the lowest: compounds 1, 4, 3 and 2 (each within the scatter of the next).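

In this assay, for the compounds shown here, the earlier compounds had only reached cyclopentyl on an oxygen on an unsaturated carbon; cyclohexyl, with one six-membered non-aromatic ring of carbon only, extends the same flat picture to a group of 6 heavy atoms, against 2 in ethyl. All three new steps lie within the scatter (a 1.3-fold lower number from compound 3 to compound 4 (0.12 log units; within the scatter)) and (a 1.6-fold lower number from compound 2 to compound 4 (0.21 log units; within the scatter)) and (a 1.2-fold higher number from compound 1 to compound 4 (0.07 log units; within the scatter)), so the four groups at this place cannot be told apart in this assay, and no trend with chain, branching or ring size can be read from them. Nothing on hand offers an explanation for this flatness.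

Going by these compounds alone, every group at this place so far is a plain saturated carbon group without hydrogen-bond donors or acceptors, so it remains open whether an amine, a carboxylic acid or a phenyl group on the same oxygen would give a step beyond the scatter. The rest of the core is the same in all four compounds, which leaves the effect of any change elsewhere in the structure unknown.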